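A Second Ring Nitrogen on a Weak Growth Inhibitor

The compounds below may be only part of what the source reports. "The series", "measured", "known", "first", "only" and "open" are said of these compounds alone.

Of the compounds shown here, three sharing one core have been tested in a functional assay on NCI-H460 cells (Homo sapiens) for inhibition, read by sulforhodamine B assay, with a stated time of 48 h; a lower number here means a stronger inhibitor of growth, a higher number a weaker inhibitor of growth. Compound 1 `COC(=O)c1sc2cc(Nc3ccc(OC)cc3)cnc2c1N` gives 95000 nM in this assay. Compound 2 `COC(=O)c1sc2cc(Nc3cc(OC)cc(OC)c3)cnc2c1N` gives 150000 nM. These two sit within the scatter of each other, so neither can be called the stronger. Compound 3 `COC(=O)c1sc2cc(Nc3ccccn3)cnc2c1N` gives only a limit, > 150000 nM, and no number. This is the limit of > 150000 nM in this assay, at which 1 of the 3 values shown sits. Compound 3 therefore stands at the weak end of what this assay can report, and nothing separates it from a compound that does not slow growth at all.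

Compound 4 `COC(=O)c1sc2cc(Nc3ncccn3)cnc2c1N` differs from compound 3 in one place: pyrimidin-2-yl in place of pyridin-2-yl on a nitrogen on an aromatic ring. Within the data shown here, no pair of measured compounds shows this change, so the size of its step cannot be read from the data. Compounds 1 and 2 already sit close to the limit, and compound 3 is at it; nothing in the measured compounds shows a second ring nitrogen moving the value far. The step expected is a step that the limit leaves unreadable from compound 3 to compound 4, none beyond the scatter, and this assay may once more report only a limit. Compound 4 is thus expected to give about 200000 nM, somewhere between 80000 nM and 500000 nM.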

Compound 4, concentration for 50% growth inhibition: > 150000 nM
Compound 4 was reported as a limit (the forecaster's own chance of this, stated with the estimate: 70%); the middle value is on the limit's open side.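

Among these compounds, compound 3 and compound 4 each give only a limit and no number, so no step between them can be read: the limit of > 150000 nM in this assay, at which 2 of the 4 values shown sit.

As far as these compounds go, what stays open is whether pyrimidin-2-yl in place of pyridin-2-yl changes growth inhibition in this assay at all, and whether any change to the shared core gives a clearly stronger inhibitor.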